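Swapping the sulfonyl aryl group in a cytotoxicity series

A few compounds are considered here, and "the series" means these few. Any claim that something is new, unique, unknown or untested is made for them only; others in the source may bear on it.

Measured so far:
compound 1 `COc1cc(-c2nc(-c3ccccc3)[nH]c2-c2ccnc(NCCCNS(=O)(=O)c3ccc(Br)cc3)n2)ccc1F`: 33900 nM
compound 2 `O=S(=O)(NCCCNc1nccc(-c2[nH]c(-c3ccccc3)nc2-c2ccc(Cl)c(O)c2)n1)c1ccc(Br)cc1`: 15500 nM

Among the compounds with values here, in a functional assay on LOX IMVI cells (Homo sapiens) for cytotoxicity, read by MTT assay, with a stated time of 24 h (a lower number here means a stronger inhibitor, a higher number a weaker inhibitor), compound 2 gives the lowest of the two numbers, and its nearest neighbour is compound 1 at 33900 nM; the one measured step, a 2.2-fold lower number from compound 1 to compound 2 (0.34 log units; beyond the scatter), changes the aryl group on the shared core. Compound 3 `O=S(=O)(NCCCNc1nccc(-c2[nH]c(-c3ccccc3)nc2-c2ccc(Cl)c(O)c2)n1)c1cccc2ccccc12` differs from compound 2 elsewhere: naphthalen-1-yl in place of 4-bromophenyl on a sulfonyl sulfur. Within the data shown here, no measured step touches the group on the sulfonyl sulfur, so the step from compound 1 to compound 2 does not bear on this change, and the data give no ground to expect a shift beyond the scatter in either direction. The number for compound 3 is therefore estimated to stay close to that of compound 2, with the expected step of a 1.0-fold lower number from compound 2 to compound 3 (0.01 log units; within the scatter) and a wide range, 15000 nM between 5000 nM and 45000 nM.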

Compound 3, half-maximal inhibitory concentration: 7720 nM
Compound 3: the middle estimate sits 1.9-fold (0.29 log units) above what was measured, within the range that was stated.
By their numbers in this assay, from the lowest: compounds 3 and 2 (each within the scatter of the next); then compound 1.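

In this assay, within the data shown here, the first change on the sulfonyl sulfur gives a 2.0-fold lower number from compound 2 to compound 3 (0.30 log units; within the scatter) and so compound 2 and compound 3 cannot be told apart. Among these compounds, this is the first look at this position, and it shows that a 4-bromophenyl can give way to a naphthalen-1-yl, which has a second aromatic ring and no bromine, without a change beyond the usual scatter. Nothing shown here explains this outcome.

As far as these compounds go, what a much smaller group on the sulfonyl sulfur, such as methyl, or a ring carrying an amine or a carboxylic acid would give remains open. From the compounds shown here alone, it is also open whether naphthalen-1-yl would behave the same way alongside the 4-fluoro-3-methoxyphenyl of compound 1.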